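Removing the Hydroxy from Compound 1

The source may report more compounds than this note shows. Statements on the series, on what has been measured and on what is new or still open speak of the compounds shown alone.

In a functional assay on DU-145 cells (Homo sapiens) for inhibition, read by trypan blue exclusion, with a stated time of 96 h (on this read-out higher numbers stand for weaker inhibition of growth and lower numbers for stronger inhibition of growth), compound 1 (`COc1ccc(/C=C(/Sc2ccc(C)cc2)C(=O)c2ccc(Cl)cc2)cc1O`) gives 1000 nM. Compound 3 (`COc1ccc(/C=C(\C(=O)c2ccc(Cl)cc2)S(=O)(=O)c2ccc(C)cc2)cc1O`) is level at 1000 nM, and together they hold the lowest number of the three, while compound 2 (`COc1ccc(/C=C(\C(=O)c2ccc(Cl)cc2)S(=O)(=O)c2ccc(Br)cc2)cc1O`) gives 10000 nM. Unmeasured compound 4 (`COc1ccc(/C=C(/Sc2ccc(C)cc2)C(=O)c2ccc(Cl)cc2)cc1`) differs from compound 1 by hydrogen in place of hydroxy on an aromatic carbon, so 3-hydroxy-4-methoxyphenyl becomes 4-methoxyphenyl. Going by the values given here, no measured step touches this hydroxy. The steps of no change at the digits printed from compound 1 to compound 3 (within the scatter) and a 10-fold higher number from compound 1 to compound 2 (1.00 log units; beyond the scatter) lie elsewhere and offer only a scale, so a modest rise in this assay is expected, though none beyond the scatter remains possible. Compound 4 is estimated at 3000 nM, within 700 nM to 15000 nM. The expected change is a 3.0-fold higher number from compound 1 to compound 4 (0.48 log units; beyond the scatter).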

Compound 4, concentration for 50% growth inhibition: 1000 nM
Compound 4: middle estimate off by 3.0-fold (0.48 log units), on the high side, within the range that was stated.
By their numbers in this assay, from the lowest: compounds 1, 3 and 4 (each within the scatter of the next); then compound 2.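

Among the compounds shown, this is the only change on the 3-hydroxy-4-methoxyphenyl group, and in this assay replacing the hydroxy with hydrogen shows no change at the digits printed from compound 1 to compound 4 (within the scatter). In this pair, the hydroxy is therefore not needed to keep the growth inhibition at the level of compound 1, and the 4-methoxyphenyl group serves equally well. No available evidence bears on this result.

From the compounds shown here alone, it remains open whether an amine or a carboxylic acid at this place on the ring would hold that level. Going by these compounds, it is also open whether the same removal would read alike in the sulfonyl compounds, compound 2 and compound 3.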